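Cyclohexyl to Pentyl on the Ether of a Dioxide Core

The source may report more compounds than this note shows. Statements on the series, on what has been measured and on what is new or still open speak of the compounds shown alone.

Measured compounds:
compound 1, `[O-][n+]1nc(NCOC2CCCCC2)[n+]([O-])c2ccccc21`, 6670 nM
compound 2, `O=[N+]([O-])c1cccc(COCNc2n[n+]([O-])c3ccccc3[n+]2[O-])c1`, > 100000 nM

Among the measured compounds shown here, in a functional assay on PC-3 cells (Homo sapiens) for cytotoxicity, read by MTT assay, with a stated time of 72 h (a higher number here means a weaker inhibitor, a lower number a stronger inhibitor), compound 1 gives 6670 nM, the only numerical value shown for this series. Compound 2 gives > 100000 nM, which is a limit of the assay rather than a number. Compound 2 thus sits at the limit of > 100000 nM in this assay, at which 1 of the 2 values shown sits. For the measured compounds named here, compound 1 is therefore the one measured compound with a defined potency, and it serves as the single point of reference.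

Compound 3, `CCCCCOCNc1n[n+]([O-])c2ccccc2[n+]1[O-]`, is not yet measured. It differs from compound 1 by pentyl in place of cyclohexyl on an oxygen on a saturated carbon. The shared core and the aminomethyl ether linkage are unchanged. Going by the values given here, the swap exchanges one saturated carbon group for another of nearly the same size, and no step between measured compounds shows how such a change plays out in this assay. The expectation is for a step from compound 1 to compound 3 that stays within the usual scatter, with at most a slight weakening.

Compound 3 is accordingly estimated at 8000 nM, within a range from 3000 nM to 25000 nM, which implies an expected step of a 1.2-fold higher number from compound 1 to compound 3 (0.08 log units; within the scatter).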

Compound 3, half-maximal inhibitory concentration: 8510 nM
The estimate for compound 3 lay 1.1-fold (0.03 log units) below the measured number, within the range that was stated.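

With a 1.3-fold higher number from compound 1 to compound 3 (0.11 log units; within the scatter) as the first step that can be read in this assay, the position on an oxygen on a saturated carbon is shown to accept an open chain in place of a ring: pentyl, with no ring, keeps a defined value where cyclohexyl, with its six-membered non-aromatic ring of carbon only, gave one before. The ring itself is therefore not needed for a defined value in this cell assay, at least for this one pair of saturated carbon groups, and one pair sets no rule for the position as a whole. Among the compounds shown here, the values show only that this swap leaves the reading within the scatter, and nothing measured here gives a cause for that outcome.

Still open, from the compounds shown here alone, is whether a much shorter chain such as methyl, a longer chain such as decyl, or a pentyl chain ending in an amine or a carboxylic acid would keep a value in this same region. For the compounds shown here, compound 2 gives > 100000 nM as a limit of the assay and not a number, so no step to it can be read.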